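The source may hold more compounds than are shown below. What is called first, only, known or untested is meant among the compounds shown, and "the series" means these compounds.

Measured so far in a physicochemical assay for solubility, at pH 7.4; on this read-out higher numbers stand for higher solubility and lower numbers for lower solubility:
- compound 1 `Cc1cc(NC(=O)Nc2ccccc2OC(F)(F)F)c2ccccc2n1`: 4600 nM
- compound 2 `Cc1cc(NC(=O)Nc2ccccc2C(F)(F)F)c2ccccc2n1`: 3800 nM

These two numbers sit within the usual scatter of each other. Compound 2, at 3800 nM, therefore cannot be told apart from compound 1 on this read-out.

The next compound to be measured is compound 3 `Cc1cc(NC(=O)Nc2ccccc2[N+](=O)[O-])c2ccccc2n1`, which keeps the core of compound 2 and changes a single group: nitro in place of trifluoromethyl on an aromatic carbon. In words, nitro takes the place of trifluoromethyl on an aromatic carbon, ortho to a large group.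

Among the measured compounds shown here, only one measured step bears on this change: a 1.2-fold lower number from compound 1 to compound 2 (0.08 log units; within the scatter). There, trifluoromethyl took the place of trifluoromethoxy on an aromatic carbon, and the size of that step gives no sign of a real shift. For the measured compounds named here, no measured compound carries a nitro group, which makes this a thin guide. Going by the values given here, with only that small step to go on, no change beyond the scatter is expected in this assay.

The expected step is a 1.1-fold higher number from compound 2 to compound 3 (0.02 log units; within the scatter). For compound 3 the estimated value is 4000 nM, with an expected range of 1700 nM to 10000 nM.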

Compound 3, solubility: 200 nM
For compound 3 the middle estimate is 20-fold (1.30 log units) above the measured one; the measured number lies below the stated range.
By their numbers in this assay, from the lowest: compound 3; then compounds 2 and 1 (each within the scatter of the next).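

In this assay, this position proved not to be indifferent to the group it carries: trifluoromethyl and trifluoromethoxy could not be told apart here, yet nitro in place of trifluoromethyl gives a 19-fold lower number from compound 2 to compound 3 (1.28 log units; beyond the scatter). The change from the other earlier compound is also large, a 23-fold lower number from compound 1 to compound 3 (1.36 log units; beyond the scatter), so the drop appears against both compounds that differ from compound 3 in this one place and does not rest on a single comparison. Nothing at hand gives a measured reason for this drop.

The three compounds cannot show whether the low number belongs to nitro alone or whether other groups on this aromatic carbon, ortho to a large group, would also bring the number down; an amine, a nitrile or a carboxylic acid in the same place would help separate those two readings. Also open, from the compounds shown here alone, is whether nitro would give a similar step on a different carbon of the same ring, since every compound here carries its group in this one place.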